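Moving from a chlorohydroxyphenyl to a fluoromethoxyphenyl

A few compounds are considered here, and "the series" means these few. Any claim that something is new, unique, unknown or untested is made for them only; others in the source may bear on it.

Among the compounds with values here, compound 1 `CC(C)C[C@H](N)c1cc(C(F)(F)F)ccc1N1CCN(C(=O)C(C)Cc2ccc(Cl)cc2O)CC1` is the stronger of the two compounds measured so far in an assay on HEK293 cells for displacement of a labelled ligand from Melanocortin receptor 4 (Homo sapiens) (on this read-out lower numbers stand for stronger inhibition and higher numbers for weaker inhibition), where compound 1 gives 36 nM. Within the data shown here, its only measured neighbour is compound 2 `CC(C)C[C@H](N)c1cc(C(F)(F)F)ccc1N1CCN(C(=O)CCNC2CCCCC2)CC1`, which in this assay gives 4800 nM; the step of a 130-fold higher number from compound 1 to compound 2 (2.12 log units; beyond the scatter) replaces the whole group on the carbonyl carbon, a far larger change than the one considered here.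

Compound 3 `COc1ccc(CC(C)C(=O)N2CCN(c3ccc(C(F)(F)F)cc3[C@@H](N)CC(C)C)CC2)cc1F` keeps the core of compound 1 and the saturated chain and alters only the aromatic ring at its end: 3-fluoro-4-methoxyphenyl in place of 4-chloro-2-hydroxyphenyl on a saturated chain carbon, two bonds along the chain from a carbonyl carbon. Among the measured compounds shown here, no measured step covers an exchange of this kind; the one step available, from compound 1 to compound 2, swaps the entire side chain and cannot be read as a guide to a ring-for-ring change. The expectation is therefore a moderate step, most likely toward a higher number in this assay, but with wide uncertainty. Compound 3 is estimated at 110 nM, with a range from 25 nM to 500 nM, an expected step of a 3.1-fold higher number from compound 1 to compound 3 (0.49 log units; beyond the scatter).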

Compound 3, inhibition constant: 200 nM
Beside the measured number, compound 3's estimate is 1.8-fold (0.26 log units) below it, and the stated range covers the measured number.
By their numbers in this assay, from the lowest: compound 1; then compound 3; then compound 2.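

In this assay, the exchange on a saturated chain carbon, two bonds along the chain from a carbonyl carbon, gives a 5.6-fold higher number from compound 1 to compound 3 (0.74 log units; beyond the scatter), which shows that with the core of compound 1 and the saturated chain held fixed, the choice of end ring alone moves the number beyond the scatter, though only modestly. The other new step, a 24-fold lower number from compound 2 to compound 3 (1.38 log units; beyond the scatter), is large and exceeds the ring exchange, so the 1-(3-fluoro-4-methoxybenzyl)ethyl group still stands well apart from the 2-(cyclohexylamino)ethyl group on the carbonyl carbon, even without the 4-chloro-2-hydroxyphenyl ring. No measurement shown here accounts for the size of either step.

The exchange alters the ring's substituents all together, so these three compounds cannot separate the loss of the hydroxyl from the change of chlorine to fluorine or from the added methoxy. Also open, as far as these compounds go, is how an amine or a carboxylic acid in place of that hydroxyl would read in this assay, and whether any such ring would bring the number back toward that of compound 1.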